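A few compounds are considered here, and "the series" means these few. Any claim that something is new, unique, unknown or untested is made for them only; others in the source may bear on it.

Compound 1 `CCC(=O)Nc1c(C(O)(C(F)(F)F)C(F)(F)F)ccc2ccccc12` carries an ethyl group on its carbonyl carbon, and in a functional assay (Sus scrofa) with sulfonylurea receptors; K-ATP channels (Homo sapiens) as the target (on this read-out higher numbers stand for larger maximal responses and lower numbers for smaller maximal responses), compound 1 gives 96%. Compound 2 `O=C(Nc1c(C(O)(C(F)(F)F)C(F)(F)F)ccc2ccccc12)c1cccc(Cl)c1`, with 3-chlorophenyl in place of ethyl on a carbonyl carbon, gives 84% in this assay; the measured change is a number 12 percentage points lower from compound 1 to compound 2 (beyond the scatter). For the measured compounds named here, compound 2 therefore stands as the lower of the two numbers measured so far, with compound 1 as its only neighbour. Compound 3 `Cc1cccc(C(=O)Nc2c(C(O)(C(F)(F)F)C(F)(F)F)ccc3ccccc23)c1` differs from compound 2 by methyl in place of chloro on an aromatic carbon. Going by the values given here, no measured step swaps one small group for another on that aromatic ring; the single step available, a number 12 percentage points lower from compound 1 to compound 2 (beyond the scatter), exchanges the whole group on the carbonyl carbon and so bears on this change only loosely, showing that even a much larger change shifted the number modestly. A small step is therefore expected, no change at the digits printed from compound 2 to compound 3 (within the scatter), with no clear direction beyond the scatter. Compound 3 is estimated at 84%, within 70% to 96%.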

Compound 3, largest response reached (reported as efficacy), in percent of the reference or control that the assay uses: 97%
The estimate for compound 3 lay 13 percentage points below the measured number; measured number above the stated range.
By their numbers in this assay, from the lowest: compound 2; then compounds 1 and 3 (each within the scatter of the next).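

Methyl in place of chloro, an exchange of one heavy atom for another, gives a number 13 percentage points higher from compound 2 to compound 3 (beyond the scatter) in this assay, so this aromatic position responds to a small change and not only to replacing the whole group on the carbonyl carbon. With 3-methylphenyl in place of ethyl on the carbonyl carbon, the result is a number 1 percentage points higher from compound 1 to compound 3 (within the scatter), so an aromatic ring on the carbonyl carbon does not by itself go with the lower number seen for compound 2. Nothing available here explains the difference between chloro and methyl at this position.

Two groups at one position cannot show what the response follows. A methoxy group, a fluorine atom or an amine in the same place could help to show whether the higher number is particular to methyl.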